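The source may hold more compounds than are shown below. What is called first, only, known or untested is meant among the compounds shown, and "the series" means these compounds.

Measured in a functional assay on PC-3 cells (Homo sapiens) for cytotoxicity, read by sulforhodamine B assay, with a stated time of 48 h; on this read-out lower numbers stand for stronger inhibition and higher numbers for weaker inhibition:
- compound 1 `C[C@H]1CC[C@@H]2[C@@H](OC(=O)[C@]23CC(c2ccccc2)=NO3)[C@]2(C)C(=O)C=C[C@@]12O`: 46000 nM
- compound 2 `C[C@H]1CC[C@@H]2[C@@H](OC(=O)[C@]23CC(c2ccc(N(C)C)cc2)=NO3)[C@]2(C)C(=O)C=C[C@@]12O`: 6300 nM
- compound 3 `COc1ccc(C2=NO[C@]3(C2)C(=O)O[C@@H]2[C@H]3CC[C@H](C)[C@]3(O)C=CC(=O)[C@@]23C)cc1OC`: 25000 nM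

Compound 2 has the lowest number of the three, and its gaps to both others lie beyond the scatter. Compound 4 `C[C@H]1CC[C@@H]2[C@@H](OC(=O)[C@]23CC(c2ccccc2F)=NO3)[C@]2(C)C(=O)C=C[C@@]12O` carries 2-fluorophenyl in place of 4-(dimethylamino)phenyl on a carbon with a double bond to nitrogen. Within the data shown here, two measured steps bear on this change. Putting dimethylamino in place of hydrogen on an aromatic carbon gave a 7.3-fold lower number from compound 1 to compound 2 (0.86 log units; beyond the scatter), and replacing the same 4-(dimethylamino)phenyl with 3,4-dimethoxyphenyl gave a 4.0-fold higher number from compound 2 to compound 3 (0.60 log units; beyond the scatter). Both are modest. A higher number is therefore expected in this assay, with an estimated step of similar size: a 4.8-fold higher number from compound 2 to compound 4 (0.68 log units; beyond the scatter). The estimate for compound 4 is 30000 nM, with an expected range of 12000 nM to 70000 nM.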

Compound 4, half-maximal inhibitory concentration: 8200 nM
For compound 4 the middle estimate is 3.7-fold (0.56 log units) above the measured one, and the stated range ends above it.
By their numbers in this assay, from the lowest: compounds 2 and 4 (each within the scatter of the next); then compounds 3 and 1 (each within the scatter of the next).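

In this assay, the low number at this position turns out not to depend on the dimethylamino group: 2-fluorophenyl in place of 4-(dimethylamino)phenyl gives a 1.3-fold higher number from compound 2 to compound 4 (0.11 log units; within the scatter) and no step beyond the scatter. A single fluoro on the phenyl already gives a 5.6-fold lower number from compound 1 to compound 4 (0.75 log units; beyond the scatter) and also separates from the 3,4-dimethoxyphenyl group, with a 3.0-fold lower number from compound 3 to compound 4 (0.48 log units; beyond the scatter) on that change. Nothing measured here explains these steps. Going by these compounds, whether chloro, amino or a carboxylic acid on this phenyl would also lower the number stays open.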